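A few compounds are considered here, and "the series" means these few. Any claim that something is new, unique, unknown or untested is made for them only; others in the source may bear on it.

Measured compounds:
- compound 1 `COC(=O)/C(=C\c1ccc(O)cc1)Sc1ccnc2cc(Cl)ccc12` gives 5180 nM in a functional assay on Jurkat E6.1 cells (Homo sapiens) for cytotoxicity, read by MTT assay, with a stated time of 24 h; a higher number here means a weaker inhibitor, a lower number a stronger inhibitor
- compound 2 `COC(=O)/C(=C\c1ccc(OC(=O)c2ccc(OC)cc2)cc1)Sc1ccnc2cc(Cl)ccc12` gives 11000 nM in this assay
- compound 3 `COC(=O)/C(=C\c1ccc(OC(=O)c2cccc(OC)c2)cc1)Sc1ccnc2cc(Cl)ccc12` gives 33300 nM in this assay

Compound 3 has the highest number of the three: a 3.0-fold higher number from compound 2 to compound 3 (0.48 log units; beyond the scatter) and a 6.4-fold higher number from compound 1 to compound 3 (0.81 log units; beyond the scatter), both beyond the scatter. Compound 4 `COC(=O)/C(=C\c1ccc(OC(=O)c2ccc(OC)c(OC)c2)cc1)Sc1ccnc2cc(Cl)ccc12` differs from compound 3 by methoxy in place of hydrogen on an aromatic carbon. The measured steps touch this change only indirectly. Esterification of the phenol weakened the inhibitor in both cases, a 2.1-fold higher number from compound 1 to compound 2 (0.33 log units; beyond the scatter) and a 6.4-fold higher number from compound 1 to compound 3 (0.81 log units; beyond the scatter), and moving the single methoxy group within the benzoyl ring gave a 3.0-fold higher number from compound 2 to compound 3 (0.48 log units; beyond the scatter). Among the compounds with values here, no step adds a second methoxy group to the benzoyl ring, so the size of the coming step is not anchored by a direct precedent. Given that every enlargement of this part of the molecule so far has raised the number, a small further rise, or nothing beyond the scatter, is expected, a 1.3-fold higher number from compound 3 to compound 4 (0.10 log units; within the scatter). Compound 4 is therefore estimated at 42000 nM in this assay, with a range of 15000 nM to 120000 nM.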

Compound 4, half-maximal inhibitory concentration: 8290 nM
Compound 4: middle estimate off by 5.1-fold (0.70 log units), on the high side; the measured number lies below the stated range.
By their numbers in this assay, from the lowest: compounds 1, 4 and 2 (each within the scatter of the next, the first and the last beyond it); then compound 3.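

In this assay, adding methoxy to the aromatic ring of the (3-methoxyphenyl)carbonyl group, ortho to the existing methoxy group and para to a large group, runs against the earlier rises on esterification: a 4.0-fold lower number from compound 3 to compound 4 (0.60 log units; beyond the scatter). The (3,4-dimethoxyphenyl)carbonyl ester stays within the scatter of both neighbours, with a 1.3-fold lower number from compound 2 to compound 4 (0.12 log units; within the scatter) and a 1.6-fold higher number from compound 1 to compound 4 (0.20 log units; within the scatter), so enlarging this part of the molecule does not by itself raise the number, and only compound 3 stands apart. Nothing available accounts for the lower number at compound 4.

Going by these compounds, whether this effect is specific to methoxy stays open: hydroxy, fluoro or amino at the same ring carbon, or ethoxy in place of methoxy, would test it. Also open, on these data alone, is how a carboxylic acid in place of the methyl ester would read in this assay.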